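From pyrrolidin-1-yl to morpholin-4-yl on a carbonyl carbon

A few compounds are considered here, and "the series" means these few. Any claim that something is new, unique, unknown or untested is made for them only; others in the source may bear on it.

Measured in a functional assay on MDA-MB-231 cells (Homo sapiens) for inhibition, read by MTT assay, with a stated time of 48 h; a lower number here means a stronger inhibitor, a higher number a weaker inhibitor:
Compound 1 `CCn1c(/C=C2\SC(=O)N(CC(=O)N3CCCCC3)C2=O)nc2ccccc21`: > 50000 nM
Compound 2 `CCn1c(/C=C2\SC(=O)N(CC(=O)N3CCCC3)C2=O)nc2ccccc21`: > 50000 nM
Compound 3 `CC(C)n1c(/C=C2\SC(=O)N(CC(=O)N3CCCC3)C2=O)nc2ccccc21`: > 50000 nM

Each of these entries is a limit and not a number. Among the measured compounds shown here, for compound 2, > 50000 nM is therefore only a limit, and the limit of > 50000 nM in this assay, at which 3 of the 3 values shown sit, shows that no measured compound has left it. Compound 4 `CCn1c(/C=C2\SC(=O)N(CC(=O)N3CCOCC3)C2=O)nc2ccccc21` is unmeasured, and its change is morpholin-4-yl in place of pyrrolidin-1-yl on a carbonyl carbon. The closest measured change, a step that the two limits leave unreadable from compound 1 to compound 2, replaces one ring on the same carbonyl carbon. The other, a step that the two limits leave unreadable from compound 2 to compound 3, lies elsewhere. Neither has a readable size, so this assay offers no direction. The expected change is a number no higher from compound 2 to compound 4 (the limit leaves the size open), which means none beyond the scatter. The estimate for compound 4 is 50000 nM, with an expected range of 20000 nM to 100000 nM, and a further limit is the likeliest report.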

Compound 4, half-maximal inhibitory concentration: > 50000 nM
Compound 4: no number, only a limit; the forecaster's own chance of this, stated with the estimate: 85%; the middle value sits exactly at the limit.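

Compound 4 gives > 50000 nM, which is a limit and not a number, so its steps from compound 1 and compound 2 cannot be read. The compounds shown leave open how strongly any of them inhibits and whether the ring on the carbonyl carbon matters.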